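The source may report more compounds than this note shows. Statements on the series, on what has been measured and on what is new or still open speak of the compounds shown alone.

Compound 1 `CN(C)C(=O)c1cc2cnc(Nc3ccc(NC(=O)C4(C(=O)Nc5cccc(C(F)(F)F)c5)CC4)cc3)nc2n1C1CCCC1`: 92.7%
Compound 2 `CN(C)C(=O)c1cc2cnc(Nc3ccc(NC(=O)C4(C(=O)Nc5ccc(C(F)(F)F)cc5)CC4)cc3)nc2n1C1CCCC1`: 94.9%

Both measured compounds were run in a functional assay on T47D cells (Homo sapiens) for inhibition, read by CCK-8 assay, with a stated time of 72 h, tested at 10 uM; on this read-out higher numbers stand for more inhibition of growth at the one concentration tested and lower numbers for less inhibition of growth. Compound 2 gives the higher of the two numbers, but the step of a number 2.2 percentage points higher from compound 1 to compound 2 (within the scatter) lies within the scatter, so the two cannot be ranked against each other. Compound 3 `COc1ccc(NC(=O)C2(C(=O)Nc3ccc(Nc4ncc5cc(C(=O)N(C)C)n(C6CCCC6)c5n4)cc3)CC2)cc1` is not yet measured. It differs from compound 2 by methoxy in place of trifluoromethyl on an aromatic carbon. Going by the values given here, the only measured step, a number 2.2 percentage points higher from compound 1 to compound 2 (within the scatter), exchanged 3-(trifluoromethyl)phenyl for 4-(trifluoromethyl)phenyl and left the trifluoromethyl group itself in place; it bears only loosely on replacing trifluoromethyl with methoxy, and nothing measured here shows what that replacement does. Both measured numbers sit close to complete inhibition, so there is more room to fall than to rise. The expected step of a number 6.9 percentage points lower from compound 2 to compound 3 (within the scatter) in this assay is therefore a small to moderate decrease, carried with wide uncertainty. The estimate for compound 3 is 88%, within 65% to 97%.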

Compound 3, percent growth inhibition at one concentration: 96.1%
The estimate for compound 3 lay 8.1 percentage points below the measured number; the measured number falls inside the stated range.
By their numbers in this assay, from the lowest: compounds 1, 2 and 3 (each within the scatter of the next).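

In this assay, going by these compounds alone, the step of a number 1.2 percentage points higher from compound 2 to compound 3 (within the scatter) is the first measured exchange of the trifluoromethyl group itself, and it shows that methoxy can stand on this aromatic carbon, para to a large group, with no readable difference in growth inhibition. The step of a number 3.4 percentage points higher from compound 1 to compound 3 (within the scatter) agrees: 4-methoxyphenyl on the amide-type nitrogen cannot be told apart from 3-(trifluoromethyl)phenyl, so neither of the two groups nor the two placements shown can be ranked here. No measurement available here accounts for this result.

From the compounds shown here alone, all three compounds sit close to complete inhibition at the one concentration tested, so any differences among them at lower concentrations remain open. Also open, going by these compounds, is whether an amine or a carboxylic acid at this aromatic carbon would keep growth inhibition at this level.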